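Ethoxy for ethylsulfanyl on the thiocarbonyl carbon

The compounds below may be only part of what the source reports. "The series", "measured", "known", "first", "only" and "open" are said of these compounds alone.

In a functional assay on HeLa cells (Homo sapiens) for cytotoxicity, read by resazurin assay, with a stated time of 72 h (on this read-out higher numbers stand for weaker inhibition and lower numbers for stronger inhibition), compound 2 `CCSC(=S)SCC(=O)c1ccc(OC)cc1` gives 1960 nM and stands within the scatter of compound 1 `CCOC(=S)SCC(=O)c1ccc(NC(C)=O)cc1` at 3610 nM in this small series. Compound 3 `COc1ccc(C(=O)CSC(=S)SCCOc2ccccc2)cc1` gives 5460 nM and the measured step is a 2.8-fold higher number from compound 2 to compound 3 (0.44 log units; beyond the scatter) with phenoxy in place of hydrogen on a saturated chain carbon.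

Compound 4 `CCOC(=S)SCC(=O)c1ccc(OC)cc1` keeps the rest of compound 2 and changes one place. The change is ethoxy in place of ethylsulfanyl on a thiocarbonyl carbon and it sits on a thiocarbonyl carbon.

Among the compounds with values here, no measured step covers this exchange alone. The step to compound 3 concerns another place and serves only as a guide to size. Compound 1 also carries ethoxy on a thiocarbonyl carbon but differs from compound 2 elsewhere too, so it offers indirect support only. A step within the scatter is therefore expected in this assay with no firm direction. The expected change is a 1.3-fold higher number from compound 2 to compound 4 (0.11 log units; within the scatter) as an estimate. The estimated value for compound 4 is 2500 nM within an expected range from 1100 nM to 5500 nM in this read-out.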

Compound 4, half-maximal inhibitory concentration: 4640 nM
For compound 4 the middle estimate is 1.9-fold (0.27 log units) below the measured one, within the range that was stated.
By their numbers in this assay, from the lowest: compounds 2, 1, 4 and 3 (each within the scatter of the next, the first and the last beyond it).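

In this assay the exchange on the thiocarbonyl carbon can now be read alone, and ethoxy in place of ethylsulfanyl gives a 2.4-fold higher number from compound 2 to compound 4 (0.37 log units; beyond the scatter) as a modest step. So this place responds to the exchange, a point the earlier compounds left unresolved, though only one pair shows it. Methoxy in place of acetamido on an aromatic carbon gives a 1.3-fold higher number from compound 1 to compound 4 (0.11 log units; within the scatter) with ethoxy held constant, so this second exchange does not separate compound 1 from compound 4 on this read-out.

As far as these compounds go, whether the step from ethylsulfanyl to ethoxy holds with acetamido on the aromatic carbon remains open, as does the outcome with an amine or a longer chain on the thiocarbonyl carbon. No supporting data bear on the reason for the step between compound 2 and compound 4.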